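A few compounds are considered here, and "the series" means these few. Any claim that something is new, unique, unknown or untested is made for them only; others in the source may bear on it.

Of the compounds shown here, two built on one shared core have so far been tested in a functional assay on the whole organism (strain Wistar) for inhibition, with Rattus norvegicus as the target, read by paw edema, with a stated time of 4 h, at a dose of 100 mg/kg; a lower number here means less inhibition, a higher number more inhibition at the dose given (going by the name of the read-out). Compound 1 `COc1cc2c(cc1OC)C(CC(=O)O)CC2` carries a carboxylic acid at the end of its side chain, and in this assay compound 1 gives 23.9%. Compound 2 `COc1ccccc1NC(=O)CC1CCc2cc(OC)c(OC)cc21` carries an amide with a ring in place of that acid, and in this assay compound 2 gives 23.4%. These two numbers lie within the usual scatter of each other, so compound 1 stands level with compound 2 and no order between them can be read from the data. Compound 3 `COc1cc2c(cc1OC)C(CC(=O)Nc1ccccn1)CC2` has not yet been measured. It differs from compound 1 in one place: (pyridin-2-yl)amino in place of hydroxy on a carbonyl carbon. This is the same kind of change as separates compound 1 from compound 2, an acid becoming an amide that carries a ring. Since compound 2 gives 23.4% after a change of that kind, the expected change in this assay is a number 0.1 percentage points higher from compound 1 to compound 3 (within the scatter), that is none beyond the scatter. Compound 3 is therefore estimated at 24% in this assay, with a range from 12% to 36%.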

Compound 3, a percentage reported as inhibition, in the whole organism at one dose (the size of the read-out at that dose, not a potency): 29.7%
The estimate for compound 3 lay 5.7 percentage points below the measured number; measured number inside the range.
By their numbers in this assay, from the lowest: compounds 2, 1 and 3 (each within the scatter of the next).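

On the carbonyl carbon, (pyridin-2-yl)amino can take the place of hydroxy, and in this assay this gives a number 5.8 percentage points higher from compound 1 to compound 3 (within the scatter), so an amide carrying a six-membered aromatic ring with a hetero atom stays level with the carboxylic acid. On the amide-type nitrogen, pyridin-2-yl in place of 2-methoxyphenyl gives a number 6.3 percentage points higher from compound 2 to compound 3 (within the scatter), so these two ring-bearing amides cannot be told apart either, and at this position neither the acid-to-amide change nor this swap of the ring shows an effect beyond the usual scatter. No measurement is at hand that could explain these numbers.

The compounds shown leave open how a methylamino group on that carbonyl carbon, which brings no ring, or a longer chain carrying the carbonyl would read in this assay. They also leave open whether these three compounds would stay level at a dose other than the single one used here, since a reading at one dose is the size of an effect and says nothing about potency.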